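A few compounds are considered here, and "the series" means these few. Any claim that something is new, unique, unknown or untested is made for them only; others in the source may bear on it.

Compound 1 `O=C(Nc1ccc(-c2cscn2)cc1)[C@H]1CCCN(Cc2ccc(F)c(F)c2)C1` gives 270 nM in a functional assay on A-375 cells (Homo sapiens) for activation, with a stated time of 3 days; on this read-out lower numbers stand for an effect already at smaller amounts and higher numbers for an effect only at larger amounts of compound. Compound 2 `O=C(Nc1ccc(-c2cscn2)cc1)C1CCCN(Cc2ccc3cn[nH]c3c2)C1` reaches only a limit of this assay, recorded as > 20000 nM; this is the limit of > 20000 nM in this assay, at which 1 of the 3 values shown sits. Compound 3 `O=C(Nc1ccc(-c2ccncc2)cc1)C1CCCN(Cc2ccc(F)c(F)c2)C1` stands highest of the two numbers with 1180 nM, and its nearest neighbour is compound 1, whose number is lower by a margin beyond the usual scatter. The not yet measured compound 4 `O=C(Nc1ccc(-c2ccsc2)cc1)C1CCCN(Cc2ccc(F)c(F)c2)C1` differs from compound 3 in one place: thiophen-3-yl in place of pyridin-4-yl on an aromatic carbon. Among the compounds with values here, no step between measured compounds with this very change is available, so the size of the expected step from compound 3 to compound 4 rests on the two numbered values alone. A moderate move toward lower numbers is expected, a 2.6-fold lower number from compound 3 to compound 4 (0.42 log units; beyond the scatter), since the five-membered ring of compound 1 gave 270 nM. Compound 4 is therefore estimated at 450 nM, with a range from 150 nM to 1500 nM.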

Compound 4, half-maximal effective concentration: 1930 nM
For compound 4 the middle estimate is 4.3-fold (0.63 log units) below the measured one; measured number above the stated range.
By their numbers in this assay, from the lowest: compound 1; then compounds 3 and 4 (each within the scatter of the next). At a limit, above all of these: compound 2.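

On an aromatic carbon para to a large group, thiophen-3-yl in place of pyridin-4-yl leaves the read-out in this assay unchanged within the scatter: a 1.6-fold higher number from compound 3 to compound 4 (0.21 log units; within the scatter). At this position, then, neither the change of ring size nor sulfur in place of nitrogen as the hetero atom shifts the number beyond the scatter. Nothing measured here offers a reason for this. Open, going by these compounds, is whether a plain phenyl ring, or a ring carrying an amine or a carboxylic acid, would hold this level at this position.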